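A few compounds are considered here, and "the series" means these few. Any claim that something is new, unique, unknown or untested is made for them only; others in the source may bear on it.

Compound 2 `CC(C)c1ccccc1OS(=O)(=O)c1cccc(NC(=O)CCl)c1` gives 3900 nM in a functional assay on M21 cells (Homo sapiens) for antiproliferative activity, read by sulforhodamine B assay, with a stated time of 48 h (a higher number here means a weaker inhibitor, a lower number a stronger inhibitor), the lowest of the two numbers obtained so far. Within the data shown here, compound 1 `CC(=O)Nc1cccc(S(=O)(=O)Oc2ccccc2C(C)C)c1` gives 31000 nM in this assay, and the step of a 7.9-fold lower number from compound 1 to compound 2 (0.90 log units; beyond the scatter) is the only measured step in the set. Compound 3 `CC(C)c1ccccc1OS(=O)(=O)c1cccc(NC(=O)CCCl)c1` differs from compound 2 by chloromethyl in place of chloro on a saturated chain carbon bound to a carbonyl carbon. Among the measured compounds shown here, no measured step covers this kind of change: the one step known concerns chloro in place of hydrogen at the same carbon, whereas here the chain grows by one carbon with the chlorine kept. That step serves only as a loose guide, indicating that this position is sensitive to what is attached, without saying in which direction a longer chain would move the number. The step of a 2.1-fold higher number from compound 2 to compound 3 (0.31 log units; beyond the scatter) is therefore expected to be small, a modest rise in the number being judged somewhat more likely than a fall. Compound 3 is estimated at 8000 nM, within a range of 2500 nM to 25000 nM.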

Compound 3, half-maximal inhibitory concentration: > 40000 nM
Compound 3 ended at the assay's limit; the forecaster's own chance of this, stated with the estimate: 5%; at least 5.0-fold (0.69 log units) between middle value and limit.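

In this assay, chloromethyl in place of chloro on a saturated chain carbon bound to a carbonyl carbon, which reads chloromethyl to 2-chloroethyl when cut one bond further out, gives an at least 10-fold higher number from compound 2 to compound 3 (1.01 log units; beyond the scatter), so this position responds not only to whether chlorine is present but also to where on the chain it stands. Compound 3 gives a limit of the assay and not a number: the limit of > 40000 nM in this assay, at which 1 of the 3 values shown sits. Chloromethyl in place of hydrogen on this same carbon gives an at least 1.2-fold higher number from compound 1 to compound 3 (0.11 log units; that floor lies within the scatter), so the lower number gained in a 7.9-fold lower number from compound 1 to compound 2 (0.90 log units; beyond the scatter) is shown to depend on the chloromethyl group, but the data do not say whether the longer chain falls level with the acetamide of compound 1 or beyond it.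

The compounds shown leave open whether bromomethyl or fluoromethyl in place of chloromethyl would keep or lower the number of compound 2. They also leave open how a chain bearing an amine or a carboxylic acid would behave at this carbon.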